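Half-life of fluoropyrimidine nucleoside amino acid esters

The source may report more compounds than this note shows. Statements on the series, on what has been measured and on what is new or still open speak of the compounds shown alone.

Three esters have been measured in an ADME assay on tissue (ZR-75-1 cells, Homo sapiens) for pharmacokinetics; on this read-out lower numbers stand for a shorter-lived compound and higher numbers for a longer-lived compound. Compound 1 `N[C@@H](CC(=O)OC[C@H]1O[C@@H](n2cc(F)c(=O)[nH]c2=O)C[C@@H]1O)C(=O)O` gives 0.223 h. Compound 3 `N[C@@H](CCC(=O)OC[C@H]1O[C@@H](n2cc(F)c(=O)[nH]c2=O)C[C@@H]1O)C(=O)O` gives 0.205 h; the step of a 1.1-fold higher number from compound 3 to compound 1 (0.04 log units; within the scatter) corresponds to the change (amino(carboxy)methyl in place of 2-amino-2-carboxyethyl on a saturated chain carbon bound to a carbonyl carbon). Compound 2 `N[C@@H](CCC(=O)O[C@H]1C[C@H](n2cc(F)c(=O)[nH]c2=O)O[C@@H]1CO)C(=O)O` gives 0.132 h, the lowest of the three numbers, though its gaps to compound 3 and compound 1 both lie within the scatter. The difference between the cores of compound 2 and compound 3 is not broken down here.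

Compound 4 `N[C@@H](CC(=O)O[C@H]1C[C@H](n2cc(F)c(=O)[nH]c2=O)O[C@@H]1CO)C(=O)O` is not yet measured; it carries the change (amino(carboxy)methyl in place of 2-amino-2-carboxyethyl on a saturated chain carbon bound to a carbonyl carbon), the same change as seen from compound 3 to compound 1. Since that earlier step stayed within the scatter, the step of a 1.1-fold higher number from compound 2 to compound 4 (0.04 log units; within the scatter) is expected to be similarly small. Compound 4 is therefore estimated at 0.145 h in this assay, with a range from 0.08 h to 0.26 h.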

Compound 4, half-life: 0.403 h
Estimate against measurement, compound 4: 2.8-fold (0.44 log units) below; the whole stated range lies below it.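

In this assay, amino(carboxy)methyl in place of 2-amino-2-carboxyethyl gives a 3.1-fold higher number from compound 2 to compound 4 (0.48 log units; beyond the scatter), so the change does not carry over at one size from core to core: the same change on two cores in this assay, a 1.1-fold higher number (0.04 log units; within the scatter) from compound 3 to compound 1 and a 3.1-fold higher number (0.48 log units; beyond the scatter) from compound 2 to compound 4, 2.8-fold (0.45 log units) apart, beyond the scatter of two such steps

The step therefore has to be read per core in this series: it lies beyond the scatter on the core of compound 2 and within it on the core of compound 3. Two cores give no rule for a third, and they do not show which feature of the cores sets the difference.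

Open, from the compounds shown here alone, is whether the same gap between cores appears with an amide in place of the ester, or with a chain longer than 3-amino-3-carboxypropyl.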